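This account rests on a few compounds, and the source may have more. Where it says the series, first, only, none or still open, it means among the compounds named here.

Measured compounds and values in a functional assay on MCF7 cells (Homo sapiens) for antiproliferative activity; on this read-out higher numbers stand for weaker inhibition and lower numbers for stronger inhibition:
compound 1, `C=CCCCn1c(Cc2cc(OC)c(OC)c(OC)c2)nc2c(N)nc(F)nc21`, 44700 nM;
compound 2, `CCCCn1c(Cc2c(Br)c(OC)c(OC)c(OC)c2Br)nc2c(N)ncnc21`, 30200 nM;
compound 3, `COc1cc(Cc2nc3c(N)ncnc3n2CCOC(C)C)cc(OC)c1OC`, 38900 nM.

The three values sit close together. The gaps from compound 1 to compound 3 and from compound 1 to compound 2 both stay within the usual scatter, so compound 1 cannot be set apart from either of them on these numbers.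

Compound 4, `CCCCn1c(Cc2cc(OC)c(OC)c(OC)c2)nc2c(N)nc(F)nc21`, differs from compound 1 in one place: methyl in place of vinyl on a saturated chain carbon, three bonds along the chain from an aromatic nitrogen. For the measured compounds named here, no pair of measured compounds shows the effect of such a change here, so there is nothing to build a direction on. The step of a 1.1-fold lower number from compound 1 to compound 4 (0.05 log units; within the scatter) is expected to be small, no larger than the scatter itself. Compound 4 is therefore estimated at 40000 nM, with a range from 18000 nM to 90000 nM.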

Compound 4, half-maximal inhibitory concentration: 24000 nM
The estimate for compound 4 lay 1.7-fold (0.22 log units) above the measured number, and the stated range covers the measured number.
By their numbers in this assay, from the lowest: compounds 4, 2, 3 and 1 (each within the scatter of the next).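

In this assay, the change from pent-4-en-1-yl to butyl is a 1.9-fold lower number from compound 1 to compound 4 (0.27 log units; within the scatter) and so gives no clear shift at this place on the chain. This is the first pair shown that differs in one place, and it shows that vinyl can give way to methyl here without a step beyond the scatter. No measurement shown offers an explanation for the step.

What the compounds leave open is how an amine, a carboxylic acid or a longer chain would fare at this place. Whether the same swap behaves alike on another core also stays unanswered.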